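Reversing a large lipophilicity step with a dimethylated lactam

A few compounds are considered here, and "the series" means these few. Any claim that something is new, unique, unknown or untested is made for them only; others in the source may bear on it.

Compound 3 `CN(c1ccccc1)c1cnc(NCc2c(F)ccc3c2CCO3)n2cnnc12` gives 3.6 in a physicochemical assay for lipophilicity, using the shake flask method, in phosphate buffer, measured as octanol-water partition, with a stated time of 30 min, at pH 7.4 (a lower number here means a more polar compound, a higher number a more lipophilic compound), the highest of the three numbers measured; compound 2 `Fc1ccc2c(c1CNc1ncc(Oc3ccccc3)c3nncn13)CCO2` with 3.5 lies within the scatter of it, while compound 1 `O=C1CCCN1c1cnc(NCc2c(F)ccc3c2CCO3)n2cnnc12` with 1.3 sits far lower. Compound 4 `CC1(C)CC(=O)N(c2cnc(NCc3c(F)ccc4c3CCO4)n3cnnc23)C1` differs from compound 3 in one place: 4,4-dimethyl-2-oxopyrrolidin-1-yl in place of methyl(phenyl)amino on an aromatic carbon. The relevant measured step runs the other way, a number 2.30 log units higher from compound 1 to compound 3 (beyond the scatter), so a large drop is expected. Since compound 1 gives 1.3 with the plain 2-oxopyrrolidin-1-yl, and compound 4 carries the 4,4-dimethyl variant, the expected fall is somewhat smaller, a number 1.50 log units lower from compound 3 to compound 4 (beyond the scatter). Compound 4 is therefore estimated at 2.1, with a range from 1.5 to 2.7.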

Compound 4, distribution coefficient: 2
Compound 4: middle estimate off by 0.10 log units, on the high side; low and high end bracket the measured number.
By their numbers in this assay, from the lowest: compound 1; then compound 4; then compounds 2 and 3 (each within the scatter of the next).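

In this assay this position now holds a second lactam set against the two aryl groups, with a number 1.60 log units lower from compound 3 to compound 4 (beyond the scatter) and a number 1.50 log units lower from compound 2 to compound 4 (beyond the scatter) as large steps that keep the 4,4-dimethyl-2-oxopyrrolidin-1-yl group well apart from methyl(phenyl)amino and phenoxy. The lactam ring itself also proves open to change, with a number 0.70 log units higher from compound 1 to compound 4 (beyond the scatter) as a modest step that covers only part of the distance to compound 3. Nothing available explains these steps.

From the compounds shown here alone, how a piperidin-2-one or a single methyl on the 2-oxopyrrolidin-1-yl ring would stand at this position remains open.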